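Swapping the aryl group on the pyridazinone nitrogen

The source may report more compounds than this note shows. Statements on the series, on what has been measured and on what is new or still open speak of the compounds shown alone.

Compound 2 `COc1cc2c(Oc3ccc(NC(=O)c4nn(-c5ccccc5C(F)(F)F)c(=O)cc4C)cc3F)ccnc2cc1OCCCN1CCC(C)CC1` gives 200 nM in a functional assay on NCI-H460 cells (Homo sapiens) for inhibition, read by MTT assay, with a stated time of 72 h; a higher number here means a weaker inhibitor, a lower number a stronger inhibitor. Its companion compound 1 `COc1cc2c(Oc3ccc(NC(=O)c4nn(-c5ccccc5C(F)(F)F)c(=O)cc4C)cc3F)ccnc2cc1OCCCN1CCCC1` gives 210 nM, and the step of a 1.1-fold lower number from compound 1 to compound 2 (0.02 log units; within the scatter) leaves the two essentially indistinguishable. Compound 3 `COc1cc2c(Oc3ccc(NC(=O)c4nn(-c5cccc(F)c5)c(=O)cc4C)cc3F)ccnc2cc1OCCCN1CCC(C)CC1` has not yet been measured; it differs from compound 2 by 3-fluorophenyl in place of 2-(trifluoromethyl)phenyl on an aromatic nitrogen. Going by the values given here, no measured step touches this part of the molecule: the only step in hand, a 1.1-fold lower number from compound 1 to compound 2 (0.02 log units; within the scatter), concerns the amine at the end of the chain and says nothing about the aryl group on the ring nitrogen. With no guidance from the data, no change beyond the scatter is expected, and the step of a 1.3-fold higher number from compound 2 to compound 3 (0.10 log units; within the scatter) is the estimate, with a wide allowance for an effect in either direction. Compound 3 is therefore expected to give 250 nM, within 80 nM to 800 nM.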

Compound 3, half-maximal inhibitory concentration: 250 nM
Beside the measured number, compound 3's estimate shows no gap at the digits printed; the measured number falls inside the stated range.
By their numbers in this assay, from the lowest: compounds 2, 1 and 3 (each within the scatter of the next).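

In this assay, going by these compounds alone, the first measured change to the aryl group on the aromatic nitrogen gives a 1.3-fold higher number from compound 2 to compound 3 (0.10 log units; within the scatter) and stays within the scatter. This position therefore accepts 3-fluorophenyl as readily as 2-(trifluoromethyl)phenyl, although the group has fewer heavy atoms, loses fluorines and moves its substituent to another place on the phenyl ring. The data give no reason for this outcome. Because the substituent differs in both kind and place, the compounds shown cannot separate the contribution of either, and they leave open whether plain phenyl or 2-fluorophenyl would read the same. Also open, from the compounds shown here alone, is whether a phenyl ring bearing an amine or a carboxylic acid, or a methyl group in place of the aryl ring, would stay in this range.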